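Chloro for Bromo on the Phenoxy Ring

The source may report more compounds than this note shows. Statements on the series, on what has been measured and on what is new or still open speak of the compounds shown alone.

Compound 2 `NC1=NC2(CCOCC2)N(OCCCOc2cccc(Br)c2)C(N)=N1` is one of two compounds tested in an assay on isolated protein for inhibition of Dihydrofolate reductase (Homo sapiens), read by spectrophotometry, using NADPH, with stated times of 5 s and 6 min, tested at 5 uM; a lower number here means a weaker effect, a higher number a stronger effect of the compound at the concentration tested. Going by the values given here, compound 2 gives 86.7%, the only plain number in the set. Compound 1 `NC1=NC2(CCOCC2)N(OCCCOc2ccc(Cl)cc2)C(N)=N1` sits at a limit of the assay, > 90%, and so offers no number (the limit of > 90% in this assay, at which 1 of the 2 values shown sits). Among the compounds with values here, the single measured step, a number at least 3.3 percentage points lower from compound 1 to compound 2 (that floor lies within the scatter), changes both the halogen and its place on the ring at once, so it speaks only loosely to the present question. Compound 3 `NC1=NC2(CCOCC2)N(OCCCOc2cccc(Cl)c2)C(N)=N1` has not yet been measured. It differs from compound 2 by chloro in place of bromo on an aromatic carbon. With only one, mixed step to lean on, and that step within the scatter, no shift beyond the scatter is expected here. Compound 3 is therefore expected to give about 85%, within a range from 70% to 95%, and the expected step is a number 1.7 percentage points lower from compound 2 to compound 3 (within the scatter).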

Compound 3, a percentage reported as inhibition, at one concentration (the size of the read-out at that concentration, not a potency): 83.2%
Estimate against measurement, compound 3: 1.8 percentage points above; low and high end bracket the measured number.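

Going by these compounds alone, compound 3 gives the first reading of the halogen alone: with its place on the ring held fixed, chloro in place of bromo gives a number 3.5 percentage points lower from compound 2 to compound 3 (within the scatter), so compound 2 and compound 3 cannot be told apart in this assay. Compound 3 also keeps the chlorine and moves it, as 3-chlorophenyl in place of 4-chlorophenyl, and this step reads a number at least 6.8 percentage points lower from compound 1 to compound 3 (that floor lies within the scatter). That step is only a floor, because compound 1 stands at a limit and not at a plain number: the limit of > 90% in this assay, at which 1 of the 3 values shown sits.

Going by these compounds, how far apart compound 1 and compound 3 truly lie therefore stays open. Also open, on these data alone, is what another group on this aromatic carbon would give, such as fluoro, methoxy, a nitrile or an amine, and what a longer chain between the phenoxy ring and the core would give.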